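Tail variation on the shared core: compound 1 to compound 4

A few compounds are considered here, and "the series" means these few. Any claim that something is new, unique, unknown or untested is made for them only; others in the source may bear on it.

Working notes on the series. The shared core is that of compound 1 `COc1cc2c(Oc3c(F)cc(NC(=O)NN4C(=O)CSC4c4c(F)cccc4F)cc3F)ccnc2cc1OCCCN1CCCC1`, which in a functional assay on HT-29 cells (Homo sapiens) for antiproliferative activity, read by MTT assay, with a stated time of 72 h (a higher number here means a weaker inhibitor, a lower number a stronger inhibitor), gives 230 nM. Compound 3 `COc1cc2c(Oc3c(F)cc(NC(=S)NN4C(=O)CSC4c4c(F)cccc4F)cc3F)ccnc2cc1OCCCN1CCCC1` gives 410 nM in this assay, and compound 2 `COc1cc2c(Oc3c(F)cc(NC(=O)NN4C(=O)C(C)(C)SC4c4c(F)cccc4F)cc3F)ccnc2cc1OCCCN1CCCC1` gives 950 nM. Compound 1 holds the lowest of the three numbers; its gap to compound 3 is within the scatter, so no order can be read between those two, while its gap to compound 2 lies beyond the scatter. Among the compounds with values here, no pair of measured compounds differs in only one place, so no single-point step is available as a guide.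

Compound 4 `CCN1CCN(CCCCOc2cc3nccc(Oc4c(F)cc(NC(=O)NN5C(=O)CSC5c5c(F)cccc5F)cc4F)c3cc2OC)CC1` differs from compound 1 in one place: (4-ethylpiperazin-1-yl)methyl in place of pyrrolidin-1-yl on a saturated chain carbon, three bonds along the chain from an oxygen on an aromatic ring. The rest of the molecule is unchanged. Within the data shown here, none of the differences among compounds 1, 2 and 3 touches this part of the molecule, so the measured numbers give no direct precedent for the change. The expected step of a 1.3-fold higher number from compound 1 to compound 4 (0.12 log units; within the scatter) is therefore estimated as small, not beyond the scatter, with no clear direction. Compound 4 is expected to give 300 nM in this assay, with an estimated range from 100 nM to 900 nM.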

Compound 4, half-maximal inhibitory concentration: 830 nM
Compound 4: middle estimate off by 2.8-fold (0.44 log units), on the low side; low and high end bracket the measured number.
By their numbers in this assay, from the lowest: compounds 1 and 3 (each within the scatter of the next); then compounds 4 and 2 (each within the scatter of the next).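

Within the data shown here, this is the first step that touches the tail, and in this assay the change of pyrrolidin-1-yl to (4-ethylpiperazin-1-yl)methyl gives a 3.6-fold higher number from compound 1 to compound 4 (0.56 log units; beyond the scatter) on a saturated chain carbon, three bonds along the chain from an oxygen on an aromatic ring. The position therefore responds to this change, and the tail cannot be treated as a part of the molecule where any such swap passes without effect on the number. Nothing at hand bears on the reason for this step.

The step alters the terminal ring and the chain together, read one bond further out as 3-(pyrrolidin-1-yl)propyl to 4-(4-ethylpiperazin-1-yl)butyl, so the compounds shown leave open which of the two accounts for it; 4-(pyrrolidin-1-yl)butyl and 3-(4-ethylpiperazin-1-yl)propyl would separate them. Also open are whether a morpholine ring or a dimethylamino group on the chain behaves like either amine shown, and whether the step carries over to the parts that differ in compound 2 and compound 3.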